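The source may report more compounds than this note shows. Statements on the series, on what has been measured and on what is new or still open speak of the compounds shown alone.

Notes on the series in a functional assay on THP-1 cells (Homo sapiens) for cytotoxicity, read by MTT assay, with a stated time of 24 h; a lower number here means a stronger inhibitor, a higher number a weaker inhibitor.

Compound 1 `Cc1ccc(/C=C2\CC[C@H]3C(C)(C)CCC[C@]3(C)[C@H]2CCC(C)CC(=O)O)cc1`: > 200000 nM, a limit of the assay and not a number.
Compound 2 `CC(CC[C@H]1/C(=C/c2ccc(Cl)cc2)CC[C@H]2C(C)(C)CCC[C@]12C)CC(=O)O`: > 200000 nM, likewise a limit and not a number.

Compound 2 therefore stands at the upper edge of what this assay reports; both values shown sit at the same limit (the limit of > 200000 nM in this assay, at which 2 of the 2 values shown sit). Among the measured compounds shown here, the single measured step, a step that the two limits leave unreadable from compound 1 to compound 2, is left unreadable by the two limits and gives no size that can be carried forward. Compound 3 `CC(CC[C@H]1/C(=C/c2ccc(Br)cc2)CC[C@H]2C(C)(C)CCC[C@]12C)CC(=O)O` differs from compound 2 by bromo in place of chloro on an aromatic carbon. For the measured compounds named here, the only measured step changes the same aromatic carbon, yet has no readable size, so no step beyond the scatter is expected in this assay , and a further limit is the most likely outcome. Compound 3 is estimated at 300000 nM, with a range from 150000 nM to 1000000 nM. The step this estimate implies, a step that the limit leaves unreadable from compound 2 to compound 3, is expected to be nil.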

Compound 3, half-maximal inhibitory concentration: > 200000 nM
Compound 3: a limit, no number; the forecaster's own chance of this, stated with the estimate: 85%; the middle value lies beyond the limit too.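

No new step can be read among compound 1, compound 2 and compound 3 in this assay, as all three values are limits and not numbers: the limit of > 200000 nM in this assay, at which 3 of the 3 values shown sit.

The compounds shown leave open whether methyl, chloro and bromo differ at all in this assay, and how far each compound lies beyond the limit.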